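Swapping tert-butyl for ethyl on the outer aromatic ring

The source may hold more compounds than are shown below. What is called first, only, known or untested is meant among the compounds shown, and "the series" means these compounds.

Three measured compounds share one core and differ only in the group on the outer aromatic ring. Compound 1 `CC(C)(C)c1ccc(-c2ccc(-c3ccc(C(=N)N)cc3)o2)cc1` carries tert-butyl there, compound 2 `N=C(N)c1ccc(-c2ccc(-c3ccc(Br)cc3)o2)cc1` bromo, and compound 3 `N=C(N)c1ccc(-c2ccc(-c3ccc([N+](=O)[O-])cc3)o2)cc1` nitro. In a functional assay on MDA-MB-468 cells (Homo sapiens) for cytotoxicity, read by MTT assay, with a stated time of 96 h (on this read-out higher numbers stand for weaker inhibition and lower numbers for stronger inhibition), compound 1 gives 3800 nM, compound 2 gives 2500 nM, and compound 3 gives 3400 nM. Compound 1 shows the highest of the three numbers, yet the gaps are small: a 1.5-fold lower number from compound 1 to compound 2 (0.18 log units; within the scatter), a 1.1-fold lower number from compound 1 to compound 3 (0.05 log units; within the scatter), and between the other two a 1.4-fold higher number from compound 2 to compound 3 (0.13 log units; within the scatter). All three changes at this position stay within the scatter.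

Compound 4 `CCc1ccc(-c2ccc(-c3ccc(C(=N)N)cc3)o2)cc1` is not yet measured. It differs from compound 1 in one place: ethyl in place of tert-butyl on an aromatic carbon. The steps from compound 1 to compound 2 and from compound 1 to compound 3 bear on this change, since each also replaces tert-butyl at the same position, and neither moved the number beyond the scatter. Compound 4 is therefore expected to show no step beyond the scatter, roughly a 1.1-fold lower number from compound 1 to compound 4 (0.04 log units; within the scatter). The estimate for compound 4 is 3500 nM, with a range from 1700 nM to 7500 nM.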

Compound 4, half-maximal inhibitory concentration: 3300 nM
The estimate for compound 4 lay 1.1-fold (0.03 log units) above the measured number, and the stated range covers the measured number.
By their numbers in this assay, from the lowest: compounds 2, 4, 3 and 1 (each within the scatter of the next).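

In this assay, for the compounds shown here, going from tert-butyl, with 4 heavy atoms, to ethyl, with 2, gives a 1.2-fold lower number from compound 1 to compound 4 (0.06 log units; within the scatter) and is the first step here in which one all-carbon group replaces another, so a change in the size of a carbon group alone also stays within the scatter at this position. Ethyl also shows no separation from the two groups that are not all-carbon, with a 1.0-fold lower number from compound 3 to compound 4 (0.01 log units; within the scatter) for the swap from nitro and a 1.3-fold higher number from compound 2 to compound 4 (0.12 log units; within the scatter) for the swap from bromo. All four groups at this position therefore give numbers within the scatter of one another.

Nothing shown here explains this flat result. As far as these compounds go, it remains open whether an amine, a carboxylic acid or a longer carbon chain on the same aromatic carbon would stay within the scatter too.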